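Replacing the 1,3-oxazol-2-yl group of compound 2

This account rests on a few compounds, and the source may have more. Where it says the series, first, only, none or still open, it means among the compounds named here.

Going by the values given here, in an in vivo ADME assay on the whole organism (plasma) for pharmacokinetics, with Rattus norvegicus as the target, at a dose of 50 mg/kg by the oral route (a higher number here means more compound in the circulation at the dose given, a lower number less compound in the circulation), compound 2 (`Cc1cc(C)c(NC(=O)c2sccc2S(=O)(=O)Nc2onc(C)c2Cl)c(-c2ncco2)c1`) reaches 134000 nM and so stands highest of the two compounds measured so far. Compound 1 (`CCCS(=O)(=O)c1cc(C)cc(C)c1NC(=O)c1sccc1S(=O)(=O)Nc1onc(C)c1Cl`) reaches 5450 nM on the same scale. Among the compounds with values here, the one measured step that bears on the next change is a 25-fold higher number from compound 1 to compound 2 (1.39 log units; beyond the scatter) and it lies beyond the scatter. It shows that exchanging the group on this aromatic carbon alone can shift the maximal plasma concentration a long way.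

Compound 3 (`C/C(=N\O)c1cc(C)cc(C)c1NC(=O)c1sccc1S(=O)(=O)Nc1onc(C)c1Cl`) has not yet been measured. Its difference from compound 2 is this: a group of 4 heavy atoms (2 carbon, 1 nitrogen, 1 oxygen; no ring) in place of a group of 5 heavy atoms (3 carbon, 1 nitrogen, 1 oxygen; one five-membered aromatic ring with 2 hetero atoms), on an aromatic carbon on the same core. Within the data shown here, neither measured compound carries the entering group, so the data offer no direct precedent, and a single step is thin support. With compound 2 at the top of so wide a gap, a fall is expected to be likelier than a rise. The expected change is a 4.5-fold lower number from compound 2 to compound 3 (0.65 log units; beyond the scatter) in this assay and it is estimated to be moderate in size. For compound 3 the estimated value is 30000 nM within an expected range from 6000 nM to 130000 nM at this dose.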

Compound 3, maximal plasma concentration: 14300 nM
For compound 3 the middle estimate is 2.1-fold (0.32 log units) above the measured one; the measured number falls inside the stated range.
By their numbers in this assay, from the lowest: compound 1; then compound 3; then compound 2.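

Adding a third group on this aromatic carbon shows that the maximal plasma concentration does not simply follow one of two outcomes, since in this assay the exchange of the 1,3-oxazol-2-yl group for the open-chain group of 4 heavy atoms gives a 9.4-fold lower number from compound 2 to compound 3 (0.97 log units; beyond the scatter) and the exchange of propylsulfonyl for that same group gives a 2.6-fold higher number from compound 1 to compound 3 (0.42 log units; beyond the scatter). Compound 3 therefore sits between the other two and closer to compound 1, which leaves compound 2, the only one of the three with a ring on this carbon, clearly at the top. The change from compound 2 to compound 3 removes the ring and adds a hydrogen-bond donor in a single step, so these compounds cannot separate what each of the two differences contributes.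

The compounds shown leave open whether a different five-membered aromatic ring, or a simpler group on this carbon such as a nitrile or an amine, would stand near compound 2 or nearer compound 1 in this assay. Nothing given here explains why the three groups differ in this way.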